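This account rests on a few compounds, and the source may have more. Where it says the series, first, only, none or still open, it means among the compounds named here.

Measured so far:
Compound 1 `Cc1ccc(NC(=O)Nc2cccc(CNc3ncnc4ccccc34)c2)cc1`: in a functional assay on HepG2 cells (Homo sapiens) for antiproliferative activity, read by MTT assay (on this read-out higher numbers stand for weaker inhibition and lower numbers for stronger inhibition), compound 1 gives > 50000 nM, which is a limit of the assay rather than a number.
Compound 2 `COc1ccccc1NC(=O)Nc1cccc(CNc2ncnc3ccccc23)c1`: in this assay compound 2 gives 17500 nM.
Compound 3 `COc1cc2ncnc(NCc3cccc(NC(=O)Nc4ccc(C)cc4)c3)c2cc1OC`: in this assay compound 3 gives > 50000 nM, again a limit of the assay rather than a number.

Compound 2 differs from compound 1 by a single change, (2-methoxyphenyl in place of 4-methylphenyl on an amide-type nitrogen). That change produced an at least 2.8-fold lower number from compound 1 to compound 2 (0.45 log units; beyond the scatter). Compound 4 `COc1ccccc1NC(=O)Nc1cccc(CNc2ncnc3cc(OC)c(OC)cc23)c1` has not yet been measured; it differs from compound 3 by the same change at the same place, (2-methoxyphenyl in place of 4-methylphenyl on an amide-type nitrogen). How the core of compound 3 differs from the core of compound 1 is not broken down here. For compound 4 the step is expected to be an at least 2.0-fold lower number from compound 3 to compound 4 (0.30 log units; that floor lies within the scatter), set beside the earlier step, and the expectation is loose because compound 3 sits at the limit of > 50000 nM in this assay, at which 2 of the 3 values shown sit, so the starting point itself is only a bound, just as the earlier step is only a bound. Compound 4 is therefore expected to give 25000 nM, within a range from 8000 nM to 60000 nM, with a fair chance that only a limit is reported again.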

Compound 4, half-maximal inhibitory concentration: 27200 nM
The estimate for compound 4 lay 1.1-fold (0.04 log units) below the measured number; the range from low to high includes it.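

In this assay, putting 2-methoxyphenyl in place of 4-methylphenyl on the amide-type nitrogen again goes with a lower number on the second core, an at least 1.8-fold lower number from compound 3 to compound 4 (0.26 log units; that floor lies within the scatter), so the change carries over in direction, although the floor of this step does not clear the scatter. The starting value of compound 3 is a limit of the assay and not a number, and such limits are common in this small set: the limit of > 50000 nM in this assay, at which 2 of the 4 values shown sit. The data therefore do not show that the change is worth the same amount on both cores, nor that it is worth more on one of them: the same change on two cores in this assay, an at least 2.8-fold lower number (0.45 log units; beyond the scatter) from compound 1 to compound 2 and an at least 1.8-fold lower number (0.26 log units; that floor lies within the scatter) from compound 3 to compound 4; the limit leaves it open whether they differ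

The compounds shown leave open how 4-methoxyphenyl or 2-methylphenyl would read at the same place, so the effect of the methoxy group cannot be separated from that of where it sits on the ring. They also leave open whether an amine or a carboxylic acid on that ring would move the number further on either core.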